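The source may hold more compounds than are shown below. What is called first, only, known or untested is meant among the compounds shown, and "the series" means these compounds.

Working notes on the series. Within the data shown here, compound 1 `CC(=O)N1CCN(c2ccc(Nc3nccc(-c4cn(C)c5ccccc45)n3)cc2)CC1` is the reference point: in a functional assay on MV4-11 cells (Homo sapiens) for antiproliferative activity, read by resazurin assay, with a stated time of 72 h (on this read-out lower numbers stand for stronger inhibition of growth and higher numbers for weaker inhibition of growth), compound 1 gives 252 nM, the highest of the three numbers measured so far. Compound 2 `CC(=O)N1CCN(c2ccc(Nc3ncc(C#N)c(-c4cn(C)c5ccccc45)n3)cc2)CC1` gives 30 nM. Among the measured compounds shown here, the single-point step an 8.4-fold lower number from compound 1 to compound 2 (0.92 log units; beyond the scatter) is the only change in the set where two measured compounds differ in one place. Compound 3 `CC(=O)N1CCCN(c2cccc(Nc3nccc(-c4c[nH]c5ncccc45)n3)c2)CC1` gives 20 nM; it differs from compound 1 in more than one place, so its two values are noted side by side without a step being drawn between them.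

The unmeasured compound 4 `CC(=O)N1CCN(c2ccc(Nc3nccc(-c4nn(C)c5ccccc45)n3)cc2)CC1` differs from compound 1 in one place: 1-methyl-1H-indazol-3-yl in place of 1-methyl-1H-indol-3-yl on an aromatic carbon. For the measured compounds named here, no measured step addresses this exchange; the step from compound 1 to compound 2 concerns a different site and a different group, so it offers no direct guide to the size or direction of the change here. With nothing in the measured set speaking to it, the working expectation for compound 4 is a number close to that of compound 1, with a 1.0-fold lower number from compound 1 to compound 4 (0.00 log units; within the scatter) expected to fall within the scatter, giving an estimate of 250 nM with a range from 80 nM to 800 nM.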

Compound 4, concentration for 50% growth inhibition: 181 nM
Estimate against measurement, compound 4: 1.4-fold (0.14 log units) above; low and high end bracket the measured number.
By their numbers in this assay, from the lowest: compounds 3 and 2 (each within the scatter of the next); then compounds 4 and 1 (each within the scatter of the next).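

In this assay, 1-methyl-1H-indazol-3-yl in place of 1-methyl-1H-indol-3-yl gives a 1.4-fold lower number from compound 1 to compound 4 (0.14 log units; within the scatter). Among these compounds, this is the first step read at this position, on the aromatic carbon next to the ring nitrogen, as the earlier step concerned the cyano group at a different site; here, a five-membered aromatic ring with 2 hetero atoms in place of one with 1 leaves the number within the scatter. Nothing on hand bears on why the two groups read alike.

Still open, going by these compounds, is whether the same exchange reads alike when the cyano group of compound 2 is also present on the core. Also open, on these data alone, is how the number responds at this position when an ethyl group or a longer chain stands in place of the methyl group on the 1-methyl-1H-indazol-3-yl ring.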